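A few compounds are considered here, and "the series" means these few. Any claim that something is new, unique, unknown or untested is made for them only; others in the source may bear on it.

Compound 1 `OB1OCc2ccc(-n3cc(Sc4ccc(O)cc4)c4ccccc43)cc21`: in an ADME assay on L929 cells (Mus musculus) for cytotoxicity, read by resazurin assay, with a stated time of 72 h (on this read-out higher numbers stand for weaker inhibition and lower numbers for stronger inhibition), compound 1 gives > 10 ug/mL, a limit of the assay rather than a number.
Compound 2 `OB1OCc2ccc(-n3cc(Sc4ccc5ccccc5c4)c4ccccc43)cc21`: in this assay compound 2 gives > 10 ug/mL, also a limit.
Compound 3 `Cc1cccc(C(=O)c2ccn(-c3ccc4c(c3)B(O)OC4)c2)c1`: in this assay compound 3 gives > 10 ug/mL, again a limit.

Compound 3 therefore stands where every measured compound stands, at the limit described by the limit of > 10 ug/mL in this assay, at which 3 of the 3 values shown sit, so no number places it apart from the others. Compound 4 `O=C(c1ccn(-c2ccc3c(c2)B(O)OC3)c1)C1CCCCC1` differs from compound 3 by a single change, (cyclohexyl in place of 3-methylphenyl on a carbonyl carbon). Within the data shown here, only one step between measured compounds is recorded, a step that the two limits leave unreadable from compound 1 to compound 2, and it concerns a different pair and a different part of the molecule; because both of its values are limits it cannot be read, so it gives no guide to the size or direction of the step from compound 3 to compound 4. With all three measured values sitting at the limit, compound 4 is expected to stay at that limit as well, and the expected step that the limit leaves unreadable from compound 3 to compound 4 is none beyond the scatter. The estimate for compound 4 in this assay is 30 ug/mL, between 10 ug/mL and 100 ug/mL, most likely reported once more only as a limit.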

Compound 4, half-maximal inhibitory concentration: > 10 ug/mL
Compound 4: a limit, no number (the forecaster's own chance of this, stated with the estimate: 85%); the middle value does not contradict the limit.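

No step can be read from compound 3 to compound 4, as both values are limits rather than numbers, and all the compounds share that limit: the limit of > 10 ug/mL in this assay, at which 4 of the 4 values shown sit. The compounds shown leave open at what concentration any of them would inhibit in this assay, and whether the group on the carbonyl carbon matters there.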